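The compounds below may be only part of what the source reports. "The series", "measured", "known", "first", "only" and "open" are said of these compounds alone.

Measured so far:
compound 1 `C[C@@H]1CN(c2cccc3c2C[C@H](CN(C)[C@H]2CCCc4cccnc42)NC3)C[C@H](C)N1` gives 61 nM in a functional assay on CCRF-CEM cells for antagonist activity at C-X-C chemokine receptor type 4 (Homo sapiens), read by calcium flux, with stated times of 25 min and 90 s; a higher number here means a weaker inhibitor, a lower number a stronger inhibitor.
compound 2 `CN(C[C@H]1Cc2c(cccc2N2CCN(Cc3ccccn3)CC2)CN1)[C@H]1CCCc2cccnc21` gives 4.47 nM in this assay.
compound 3 `CN(C[C@H]1Cc2c(cccc2N2CCN(c3cccc(C(F)(F)F)c3)CC2)CN1)[C@H]1CCCc2cccnc21` stands at the limit of > 16700 nM in this assay, at which 1 of the 3 values shown sits; its entry > 16700 nM is a limit of the assay, not a number.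

For the measured compounds named here, compound 3 is thus the one member of the series with no finite value in this assay; only a floor is known for it. Compound 4 `CCN1CCN(c2cccc3c2C[C@H](CN(C)[C@H]2CCCc4cccnc42)NC3)CC1` differs from compound 3 by ethyl in place of 3-(trifluoromethyl)phenyl on an amine nitrogen in a ring.

Going by the values given here, one measured step bears directly on this change: an at least 3700-fold higher number from compound 2 to compound 3 (3.57 log units; beyond the scatter), in which the same 3-(trifluoromethyl)phenyl entered on that ring nitrogen. Compound 4 removes that group again and carries a small ethyl instead. The two compounds without the aryl group set the frame. Compound 2 gives 4.47 nM in this assay. Compound 1 gives 61 nM in this assay. A large step back down is therefore expected, at least as large as the floor allows, an at least 550-fold lower number from compound 3 to compound 4 (2.74 log units; beyond the scatter). Compound 4 is expected to land near 30 nM in this assay, with a range of 8 nM to 150 nM, nearer compound 1 than compound 2 given the plain alkyl group.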

Compound 4, half-maximal inhibitory concentration: 13.8 nM
Beside the measured number, compound 4's estimate is 2.2-fold (0.34 log units) above it; the measured number falls inside the stated range.
By their numbers in this assay, from the lowest: compound 2; then compound 4; then compound 1. At a limit, above all of these: compound 3.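

In this assay, the amine nitrogen in the ring accepts ethyl where it does not accept 3-(trifluoromethyl)phenyl, with an at least 1200-fold lower number from compound 3 to compound 4 (3.08 log units; beyond the scatter) reversing the loss seen on that nitrogen in the earlier step. Going by these compounds, compound 3 is known only as a limit, not a number, so the true size of that step stays unknown: the limit of > 16700 nM in this assay, at which 1 of the 4 values shown sits. The pyridin-2-yl ring of the (pyridin-2-yl)methyl group is not needed for a low number, as a 3.1-fold higher number from compound 2 to compound 4 (0.49 log units; beyond the scatter) is only a modest loss, while a 4.4-fold lower number from compound 1 to compound 4 (0.65 log units; beyond the scatter) shows the 4-ethylpiperazin-1-yl compound ahead of the 3,5-dimethylpiperazin-1-yl compound, which differs from it at the same ring.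

The compounds shown do not separate the part played by the aromatic ring set directly on the nitrogen from that of its trifluoromethyl group; a plain phenyl or a benzyl on that nitrogen would speak to this. On these data alone, how the numbers run with a longer chain such as butyl, a hydroxyethyl group, or a bare hydrogen on that nitrogen also stays open.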